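From Benzyl to Methyl on Compound 3

This account rests on a few compounds, and the source may have more. Where it says the series, first, only, none or still open, it means among the compounds named here.

In an ADME assay on Vero cells (Chlorocebus sabaeus) for cytotoxicity (a lower number here means that less compound is tolerated, a higher number that more compound is tolerated), compound 3 (`Oc1cccc(Nc2nc(NCc3ccccc3)nc3[nH]cnc23)c1`) gives > 150000 nM, which is a limit and not a number. Compound 1 (`CNc1nc(Nc2ccc(C(C)=O)cc2)c2nc[nH]c2n1`) gives > 177000 nM, also a limit. Compound 2 (`COc1ccc(Cn2c(C)cc(OCc3cccc(F)c3)cc2=O)cc1`) gives < 6400 nM, again a limit. Compound 4 (`CNc1nc(Nc2cccc(O)c2)c2nc[nH]c2n1`) differs from compound 3 (hydrogen in place of phenyl on a saturated chain carbon bound to a nitrogen on an aromatic ring), with hydrogen in place of phenyl on a saturated chain carbon bound to a nitrogen on an aromatic ring, so that benzylamino becomes methylamino. Within the data shown here, no measured step shows this change in this assay, and no shift beyond the scatter is expected. Compound 1 also carries methylamino, and its result is the limit of > 177000 nM. The expected step is a step that the limit leaves unreadable from compound 3 to compound 4. Compound 4 is estimated at 180000 nM, with an expected range of 80000 nM to 350000 nM.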

Compound 4, half-maximal cytotoxic concentration: 168000 nM
Compound 4: the middle estimate sits 1.1-fold (0.03 log units) above what was measured; measured number inside the range.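

In this assay compound 3 gives only a limit, > 150000 nM, so the change from benzylamino to methylamino in compound 4 cannot be read as a step. The compounds shown leave open whether this change shifts the half-maximal cytotoxic concentration at all.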